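Cyclopropyl to difluorocyclohexyl on the amine of compound 1

A few compounds are considered here, and "the series" means these few. Any claim that something is new, unique, unknown or untested is made for them only; others in the source may bear on it.

Compound 1 `c1cnc2c(c1)CCC[C@@H]2N(CC1CC1)C[C@H]1Cc2c(cccc2N2CCNCC2)CN1` is the reference point of this small set. In a functional assay on CCRF-CEM cells for antagonist activity at C-X-C chemokine receptor type 4 (Homo sapiens), read by calcium flux, with stated times of 25 min and 90 s (a higher number here means a weaker inhibitor, a lower number a stronger inhibitor), compound 1 gives 26.7 nM. Compound 2 `CN(C[C@H]1Cc2c(cccc2N2CCNC(C)(C)C2)CN1)[C@H]1CCCc2cccnc21`, which carries a different methylated piperazine and a methyl on the amine, gives 33.9 nM in this assay; the two numbers lie within the usual scatter of each other, so nothing separates them, and compound 1 simply has the lower of the two values shown.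

Compound 3 `FC1(F)CCC(CN(C[C@H]2Cc3c(cccc3N3CCNCC3)CN2)[C@H]2CCCc3cccnc32)CC1` has not been measured. It differs from compound 1 in one place: 4,4-difluorocyclohexyl in place of cyclopropyl on a saturated chain carbon bound to an amine nitrogen. Among the measured compounds shown here, no pair of measured compounds shows this kind of exchange, so no measured step can be carried over. Compounds 1 and 2 show that changes at the amine substituent and at the piperazine leave the value essentially where it is.

The expectation is that the step of a 1.3-fold higher number from compound 1 to compound 3 (0.12 log units; within the scatter) stays within the usual scatter, with at most a slight weakening. Compound 3 is expected to give 35 nM in this assay, with a range of 12 nM to 100 nM.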

Compound 3, half-maximal inhibitory concentration: 498 nM
The estimate for compound 3 lay 14-fold (1.15 log units) below the measured number; measured number above the stated range.
By their numbers in this assay, from the lowest: compounds 1 and 2 (each within the scatter of the next); then compound 3.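

Among the compounds shown here, replacing cyclopropyl with 4,4-difluorocyclohexyl on a saturated chain carbon bound to an amine nitrogen gives a 19-fold higher number from compound 1 to compound 3 (1.27 log units; beyond the scatter) in this assay, which is the only single-place step in this set and lies well beyond the scatter. This shows that the position is sensitive to the group it carries, at least for this exchange, a point that compounds 1 and 2 could not establish because they differ in more than one place. The exchange replaces a group of 3 heavy atoms, all carbon, with one of 8 heavy atoms that includes 2 fluorine atoms, and nothing available here explains the weaker inhibition.

With one step, the contributions of the larger ring and the fluorine atoms cannot be separated, and the trend across substituents at this position remains undefined. Unsubstituted cyclohexyl would isolate the ring from the fluorine atoms, while cyclobutyl would show how the value responds to a smaller increase in ring size from cyclopropyl.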